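The source may report more compounds than this note shows. Statements on the series, on what has been measured and on what is new or still open speak of the compounds shown alone.

Working notes on the series.

Compound 1 `COc1ccc2c(C3(c4c[nH]c5cc(OC)ccc45)C(=O)Nc4ccccc43)c[nH]c2c1` and compound 3 `COc1ccc2c(C3(c4c[nH]c5cc(OC)ccc45)C(=O)Nc4ccc(F)cc43)c[nH]c2c1` share one core, while compound 2 `O=C1Nc2ccccc2C1(c1c[nH]c2ccc([N+](=O)[O-])cc12)c1c[nH]c2ccc([N+](=O)[O-])cc12` and compound 4 `O=C1Nc2ccc(F)cc2C1(c1c[nH]c2ccc([N+](=O)[O-])cc12)c1c[nH]c2ccc([N+](=O)[O-])cc12` share another; the difference between the two cores is not broken down here. In a functional assay on HepG2 cells (Homo sapiens) for cytotoxicity, read by MTT assay, with a stated time of 48 h (on this read-out higher numbers stand for weaker inhibition and lower numbers for stronger inhibition), compound 1 gives 12000 nM, compound 3 gives 16000 nM, and compound 2 gives 23400 nM. All three numbers sit within the usual scatter of one another, so no order among them is claimed.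

The change from compound 1 to compound 3 is fluoro in place of hydrogen on an aromatic carbon. It gave a 1.3-fold higher number from compound 1 to compound 3 (0.12 log units; within the scatter). The change from compound 2 to compound 4 is fluoro in place of hydrogen on an aromatic carbon, the same change on the other core.

Among the compounds with values here, for compound 4 the step in this assay is expected to be a 1.2-fold higher number from compound 2 to compound 4 (0.08 log units; within the scatter), resting on the single earlier instance of this change, which gave a 1.3-fold higher number from compound 1 to compound 3 (0.12 log units; within the scatter) and stayed within the scatter. Compound 4 is therefore estimated at 28000 nM, with the range 14000 nM to 60000 nM covering the scatter seen among the measured compounds.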

Compound 4, half-maximal inhibitory concentration: 23800 nM
Compound 4: middle estimate off by 1.2-fold (0.07 log units), on the high side; low and high end bracket the measured number.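

In this assay, fluoro in place of hydrogen on an aromatic carbon gave a 1.0-fold higher number from compound 2 to compound 4 (0.01 log units; within the scatter), so on the core of compound 2 this step stays within the scatter. Set beside the earlier instance on the core of compound 1, the two steps cannot be told apart: the same change on two cores in this assay, a 1.3-fold higher number (0.12 log units; within the scatter) from compound 1 to compound 3 and a 1.0-fold higher number (0.01 log units; within the scatter) from compound 2 to compound 4, 1.3-fold (0.12 log units) apart, within the scatter of two such steps. This shows that the change carried from one core to the other without a difference that can be read, but it does not show that the change has any effect on either core, and two pairs in a single cell assay say nothing about a third core or another read-out.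

The compounds shown carry only hydrogen or fluoro at this place, so it stays open how a group such as chloro, an amine or a carboxylic acid there would read in this assay. The difference between the two cores also stays unresolved, as no compound shown separates its parts.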